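The source may report more compounds than this note shows. Statements on the series, on what has been measured and on what is new or still open speak of the compounds shown alone.

Measured in a functional assay on LNCaP cells (Homo sapiens) for antiproliferative activity, read by WST assay, with a stated time of 3 days; a higher number here means a weaker inhibitor, a lower number a stronger inhibitor:

- Compound 1 `COc1cc(-c2oc3ccccc3c(=O)c2OC(C)C)cc(OC)c1OC`: 8800 nM
- Compound 2 `CCCC(C)Oc1c(-c2cc(OC)c(OC)c(OC)c2)oc2ccccc2c1=O`: 15100 nM
- Compound 3 `CCN(CC)CCCOc1c(-c2cc(OC)c(OC)c(OC)c2)oc2ccccc2c1=O`: 37600 nM

Compound 3 has the highest number of the three, making it the weakest inhibitor so far. It carries 3-(diethylamino)propyl on the oxygen where compound 1 has isopropyl and compound 2 has 1-methylbutyl. The steps to it are a 4.3-fold higher number from compound 1 to compound 3 (0.63 log units; beyond the scatter) and a 2.5-fold higher number from compound 2 to compound 3 (0.40 log units; beyond the scatter), both modest. The change from isopropyl to 1-methylbutyl, a 1.7-fold higher number from compound 1 to compound 2 (0.23 log units; within the scatter), does not separate those two compounds.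

Compound 4 `CCCCN(CCCC)CCCCOc1c(-c2cc(OC)c(OC)c(OC)c2)oc2ccccc2c1=O` differs from compound 3 as follows: (dibutylamino)methyl in place of diethylamino on a saturated chain carbon, three bonds along the chain from an oxygen on an aromatic ring. For the measured compounds named here, no measured step alters the groups on the nitrogen or the chain length beyond it, so the evidence is indirect. Going by the values given here, compound 3 is the only measured compound with a diethylamino group, and the two compounds with plain alkyl groups have lower numbers. The added carbon in compound 4 might therefore move it part of the way back toward them, though this is only a tentative expectation. A modest step to a lower number is expected in this assay, and the wide range allows for no change at all. The expected step is a 2.5-fold lower number from compound 3 to compound 4 (0.40 log units; beyond the scatter). For compound 4 the estimated value is 15000 nM, with an expected range of 3000 nM to 45000 nM.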

Compound 4, half-maximal inhibitory concentration: 7800 nM
For compound 4 the middle estimate is 1.9-fold (0.28 log units) above the measured one, and the stated range covers the measured number.
By their numbers in this assay, from the lowest: compounds 4, 1 and 2 (each within the scatter of the next); then compound 3.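

In this assay, (dibutylamino)methyl in place of diethylamino, on a saturated chain carbon three bonds along the chain from an oxygen on an aromatic ring, gives a 4.8-fold lower number from compound 3 to compound 4 (0.68 log units; beyond the scatter), a modest step beyond the scatter. This shows that a chain ending in an amine on this oxygen does not by itself go with the highest number: compound 4 lies within the scatter of compound 1, which has isopropyl at this oxygen, so the amine-bearing compounds shown here do not behave alike. Nothing measured here accounts for the step.

The change lengthens the chain and replaces the ethyl groups on the nitrogen with butyl groups in one move, so the compounds shown leave open how much of the step belongs to each; 3-(dibutylamino)propyl on the same oxygen would separate the two. They also leave open whether a still longer chain ending in dibutylamino, or a carboxylic acid at the end of the chain in place of the amine, would hold the number in this range.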